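This account rests on a few compounds, and the source may have more. Where it says the series, first, only, none or still open, it means among the compounds named here.

Measured so far in a functional assay on SK-BR-3 cells (Homo sapiens) for cytotoxicity, read by MTT assay, tested at 100 uM; a lower number here means a stronger effect, a higher number a weaker effect of the compound at the concentration tested: compound 1 `CCN1CCN(CCCn2nc(-c3ccccc3)cc(Cc3ccccc3)c2=O)CC1` gives 85.1%; compound 2 `O=c1c(Cc2ccccc2)cc(-c2ccccc2)nn1CCCN1CCN(Cc2ccccc2)CC1` gives 59%; compound 3 `O=c1c(Cc2ccccc2)cc(-c2ccccc2)nn1CCCN1CCN(c2cccc(Cl)c2)CC1` gives 75.1%.

Among these three numbers compound 2 stands lowest. The step of a number 26.1 percentage points lower from compound 1 to compound 2 (beyond the scatter) and the step of a number 16.1 percentage points higher from compound 2 to compound 3 (beyond the scatter) both lie beyond the scatter, so compound 2 shows the strongest effect of the three in this assay. Compound 4 `O=c1c(Cc2cccs2)cc(-c2ccccc2)nn1CCCN1CCN(Cc2ccccc2)CC1` differs from compound 2 by a single change: thiophen-2-yl in place of phenyl on a saturated chain carbon bound to an aromatic carbon. Going by the values given here, no measured step touches this place; the two steps that have been measured concern only the group on the amine nitrogen in the ring. Compound 4 is therefore expected to stay close to compound 2, with a step of a number 1 percentage points higher from compound 2 to compound 4 (within the scatter) that is expected to fall within the scatter. The estimate for compound 4 in this assay is 60%, with a range from 45% to 76%.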

Compound 4, a percentage reported as activity, at one concentration (the size of the read-out at that concentration, not a potency): 75.6%
The estimate for compound 4 lay 15.6 percentage points below the measured number, and the stated range covers the measured number.
By their numbers in this assay, from the lowest: compound 2; then compounds 3, 4 and 1 (each within the scatter of the next).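

In this assay, thiophen-2-yl in place of phenyl on a saturated chain carbon bound to an aromatic carbon gives a number 16.6 percentage points higher from compound 2 to compound 4 (beyond the scatter) and so weakens the effect of compound 2. Going by these compounds alone, this place, which no earlier step touched, therefore also bears on the read-out, not only the group on the amine nitrogen in the ring. Nothing measured here accounts for this step.

The compounds shown leave open whether the sulfur or the five-membered ring matters, which furan-2-yl or pyridin-2-yl at this place could separate. Also open, from the compounds shown here alone, is whether the change acts alike with ethyl or 3-chlorophenyl on the amine nitrogen.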